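This account rests on a few compounds, and the source may have more. Where it says the series, first, only, none or still open, it means among the compounds named here.

Compound 3, `CCCCCCOP(=O)(O)OCCSC(=S)N1CCCCCC1`, carries a hexyl chain and an azepan-1-yl group on the thiocarbonyl carbon. In an ADME assay on HEK293 cells (Homo sapiens) for inhibition, read by MTT assay, with stated times of 18 h and 4 h (a lower number here means a stronger inhibitor, a higher number a weaker inhibitor), compound 3 gives 70500 nM. Its nearest measured neighbour is compound 2, `CCCOP(=O)(O)OCCSC(=S)N1CCCCCC1`, which differs only in carrying a propyl chain instead of hexyl; in this assay compound 2 gives 54000 nM, and the step of a 1.3-fold higher number from compound 2 to compound 3 (0.12 log units; within the scatter) shows that lengthening the chain left the number unchanged within the scatter. Among the measured compounds shown here, the third compound measured so far, compound 1, `CCCCCCCCCCCCCCCCOP(=O)(O)OCCSC(=S)N1CCCCC1`, carries a much longer hexadecyl chain together with a piperidin-1-yl group. In this assay compound 1 reaches only a limit, > 100000 nM, so no number is known for it (the limit of > 100000 nM in this assay, at which 1 of the 3 values shown sits).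

The next compound, compound 4, `CCCCCCOP(=O)(O)OCCSC(=S)N1CCCCC1`, keeps the hexyl chain of compound 3 and changes only the ring on the thiocarbonyl carbon: piperidin-1-yl in place of azepan-1-yl on a thiocarbonyl carbon. For the measured compounds named here, no measured pair isolates this ring swap; the only piperidin-1-yl compound, compound 1, also differs in its chain and gave only a limit. With nothing pointing either way, the step of a 1.0-fold lower number from compound 3 to compound 4 (0.00 log units; within the scatter) is expected to stay within the scatter, and compound 4 is estimated to give about 70000 nM in this assay, between 30000 nM and 160000 nM.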

Compound 4, half-maximal inhibitory concentration: > 100000 nM
Compound 4 ended at the assay's limit (the forecaster's own chance of this, stated with the estimate: 30%); at least 1.4-fold (0.15 log units) between middle value and limit.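

Among the compounds shown here, compound 3 and compound 4 form the first pair that isolates the ring on the thiocarbonyl carbon, since both carry the same hexyl chain. In this assay, piperidin-1-yl in place of azepan-1-yl gives an at least 1.4-fold higher number from compound 3 to compound 4 (0.15 log units; that floor lies within the scatter), so the swap moves the number in the direction of a weaker inhibitor by an unknown amount, and the smallest size that the limit allows does not clear the usual scatter. The step between compound 1 and compound 4 cannot be read, and both piperidin-1-yl compounds, one with a hexadecyl chain and one with a hexyl chain, stop at the same limit and so give no number for this ring: the limit of > 100000 nM in this assay, at which 2 of the 4 values shown sit.

The compounds shown leave open how far past the limit compound 4 lies, and so whether the ring swap has a real effect at all. They also leave open what other rings on the thiocarbonyl carbon would do, such as pyrrolidin-1-yl or morpholin-4-yl, and whether any of them would give a readable number with the hexyl chain.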